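This account rests on a few compounds, and the source may have more. Where it says the series, first, only, none or still open, it means among the compounds named here.

Measured in a functional assay on MCF7 cells (Homo sapiens) for cytotoxicity, read by MTT assay, with a stated time of 48 h; on this read-out higher numbers stand for weaker inhibition and lower numbers for stronger inhibition:
- Compound 1 `COc1ccc(-c2nc3ccccn3c2C(=O)/C=C\Nc2ccc3[nH]ccc3c2)cc1` gives 18900 nM
- Compound 2 `COc1ccc(-c2nc3ccccn3c2C(=O)/C=C\Nc2ccc3cc[nH]c3c2)cc1` gives 19400 nM
- Compound 3 `COc1ccc(-c2nc3ccccn3c2C(=O)/C=C\Nc2cnc3ccccc3c2)cc1` gives 15000 nM

On these numbers compound 3 (15000 nM) is not separated from the other two, as all three values lie within the scatter of one another. The next structure is compound 4 `COc1ccc(-c2nc3ccccn3c2C(=O)/C=C\Nc2ccc3ncccc3c2)cc1`, which has the same atoms as compound 3, joined differently: quinolin-6-yl in place of quinolin-3-yl on an amine nitrogen. In words, quinolin-6-yl stands in place of quinolin-3-yl on the amine nitrogen.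

Within the data shown here, the closest precedent exchanges 1H-indol-5-yl for 1H-indol-6-yl on the same amine nitrogen and gives a 1.0-fold higher number from compound 1 to compound 2 (0.01 log units; within the scatter). Exchanging either indolyl group for quinolin-3-yl gives a 1.3-fold lower number from compound 1 to compound 3 (0.10 log units; within the scatter) and a 1.3-fold lower number from compound 2 to compound 3 (0.11 log units; within the scatter). None of these three steps leaves the scatter. No exchange between two quinolinyl groups has been measured, so the precedent is indirect and the range is kept wide. In this assay no step beyond the scatter is expected, in either direction. The expected step is a 1.1-fold higher number from compound 3 to compound 4 (0.03 log units; within the scatter). Compound 4 is estimated at 16000 nM (expected range 8000 nM to 30000 nM).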

Compound 4, half-maximal inhibitory concentration: 11600 nM
Compound 4: the middle estimate sits 1.4-fold (0.14 log units) above what was measured; low and high end bracket the measured number.
By their numbers in this assay, from the lowest: compounds 4, 3, 1 and 2 (each within the scatter of the next).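

In this assay, among these compounds, the first exchange between two quinolinyl groups on the amine nitrogen gives a 1.3-fold lower number from compound 3 to compound 4 (0.11 log units; within the scatter) and stays within the scatter, as the exchange between the two indolyl groups did. Quinolin-6-yl set against the indolyl groups gives a 1.7-fold lower number from compound 2 to compound 4 (0.22 log units; within the scatter) and a 1.6-fold lower number from compound 1 to compound 4 (0.21 log units; within the scatter) and these wider steps also stay within the scatter, so neither the attachment point of the quinolinyl group nor the choice between indolyl and quinolinyl separates the four compounds at this position. No supporting data are available to explain the small size of these steps.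

Still open, from the compounds shown here alone, is whether any group on this amine nitrogen can produce a step beyond the scatter, as all four compounds carry an indolyl or quinolinyl group there. A plain phenyl, a phenyl bearing a carboxylic acid or a morpholine, a saturated amine such as piperidin-4-yl, or a longer alkyl chain would test how far this insensitivity extends.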